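Series notes: fluoro to dimethylamino

The source may hold more compounds than are shown below. What is called first, only, known or untested is meant among the compounds shown, and "the series" means these compounds.

Values so far in a physicochemical assay for lipophilicity, at pH 7.4; on this read-out lower numbers stand for lower lipophilicity and higher numbers for higher lipophilicity
- compound 1 `CCc1ccc(N(CC(C)C)S(=O)(=O)c2ccc3c(c2)CCC(C2CCOCC2)O3)cc1` gives 5.38
- compound 2 `CC(C)CN(c1ccc(F)cc1)S(=O)(=O)c1ccc2c(c1)C(O)CC(C1CCOCC1)O2` gives 3.39

Compound 2 is the lower of the two at 3.39, and compound 1 gives 5.38, a gap beyond the usual scatter. These two compounds differ in more than one place, so the gap is not assigned to any single change. Within the data shown here, no measured pair yet differs in one place only.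

Compound 3 `CC(C)CN(c1ccc(N(C)C)cc1)S(=O)(=O)c1ccc2c(c1)C(O)CC(C1CCOCC1)O2` keeps the rest of compound 2 but carries dimethylamino in place of fluoro on an aromatic carbon, para to a large group (dimethylamino in place of fluoro on an aromatic carbon). Among the measured compounds shown here, with no measured step for this swap, the expectation rests on the structural change alone, starting from compound 2 at 3.39. Neither group has a ring or a net charge. In this assay, no step beyond the scatter is expected, and the estimate, slightly upward if anything, is a number 0.16 log units higher from compound 2 to compound 3 (within the scatter). Compound 3 is expected at 3.55, within an estimated range of 3 to 4.1.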

Compound 3, distribution coefficient: 3.51
For compound 3 the middle estimate is 0.04 log units above the measured one, and the stated range covers the measured number.
By their numbers in this assay, from the lowest: compounds 2 and 3 (each within the scatter of the next); then compound 1.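

In this assay, among these compounds, dimethylamino in place of fluoro on an aromatic carbon, para to a large group, reads as a number 0.12 log units higher from compound 2 to compound 3 (within the scatter), the first step between compounds that differ in one place. At this position, then, the two groups cannot be told apart on this read-out, even though dimethylamino has 3 heavy atoms and 1 hydrogen-bond acceptor, while fluoro has 1 heavy atom and 0 hydrogen-bond acceptors. No measurement at hand explains why the two groups read alike.

From the compounds shown here alone, it remains open whether a group of another kind at this position, such as a carboxylic acid or a primary amine, would give a step beyond the scatter. The reading also rests on a single pair sharing one core, so it is not known whether the same swap would read alike with another part of the molecule changed.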